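A few compounds are considered here, and "the series" means these few. Any claim that something is new, unique, unknown or untested is made for them only; others in the source may bear on it.

Of the compounds shown here, three built on one shared core have been measured in a physicochemical assay for lipophilicity, at pH 7.4; a lower number here means a more polar compound, a higher number a more lipophilic compound. Compound 1 `CNC(=O)c1cc(C(=O)NC2CC2)cn(CC2CCOCC2)c1=O` gives 1.5 in this assay. Compound 2 `CNC(=O)c1cc(C(=O)NCC(C)C)cn(Cc2ccccc2)c1=O` gives 4.3 in this assay. Compound 3 `CNC(=O)c1cc(C(=O)NC)c(=O)n(Cc2ccccc2)c1` gives 2.4 in this assay. Compound 1 therefore stands lowest of the three: compound 3 is its nearest neighbour and lies higher by a margin beyond the scatter, and compound 2 lies furthest above it, also beyond the scatter. Among the measured compounds shown here, only one measured pair differs in a single place, and that step, a number 1.90 log units lower from compound 2 to compound 3 (beyond the scatter), shows how far this assay can move when a saturated chain carbon bound to an amide-type nitrogen changes from isopropyl to hydrogen. Compound 4 `CNC(=O)c1cc(C(=O)NC2CC2)cn(Cc2ccc(F)cc2)c1=O` has not yet been measured. It differs from compound 1 in one place: 4-fluorophenyl in place of oxan-4-yl on a saturated chain carbon bound to an aromatic nitrogen. For the measured compounds named here, no measured pair carries this same exchange, and the single known step sits at a different position, so it sets only the scale that an exchange of one group for another can reach. The exchange here removes a ring that carries a hydrogen-bond acceptor and brings in an aromatic ring with none. Compound 4 is therefore expected to rise above its parent by an estimated a number 1.70 log units higher from compound 1 to compound 4 (beyond the scatter). Compound 4 is estimated at 3.2, with a likely range from 2.6 to 3.8.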

Compound 4, distribution coefficient: 3.2
The estimate for compound 4 equals the measured number at the digits printed; low and high end bracket the measured number.
By their numbers in this assay, from the lowest: compound 1; then compound 3; then compound 4; then compound 2.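

Among the compounds shown here, the change at a saturated chain carbon bound to an aromatic nitrogen can now be read for the first time: in this assay, 4-fluorophenyl in place of oxan-4-yl gives a number 1.70 log units higher from compound 1 to compound 4 (beyond the scatter). For the compounds shown here, until now, the only single-place step was a number 1.90 log units lower from compound 2 to compound 3 (beyond the scatter), at a saturated chain carbon bound to an amide-type nitrogen, so the new step shows that a second position on the shared core can also move this number beyond the scatter. The step carries several differences at once, since oxan-4-yl is a six-membered non-aromatic ring with 1 hydrogen-bond acceptor, whereas 4-fluorophenyl is a six-membered aromatic ring of carbon only, with 0 hydrogen-bond acceptors and a fluorine.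

The compounds shown do not separate these differences, and it stays open where cyclohexyl, which has neither the ring oxygen nor the aromatic ring, or piperidin-4-yl, a ring amine, would fall at this place relative to compound 1 and compound 4. Nothing in the material shown gives a measured explanation for the size of this step.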